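Alkynyl uracil series: aryl-to-alkyl-to-aryl swap at the alkyne

This account rests on a few compounds, and the source may have more. Where it says the series, first, only, none or still open, it means among the compounds named here.

Compound 2 `CCCCCCCCC#Cc1cn(C/C=C\CN2C(=O)c3ccccc3C2=O)c(=O)[nH]c1=O` gives 39000 nM in a functional assay on HepG2 cells (Homo sapiens) for antiproliferative activity, read by MTT assay, with a stated time of 3 days (on this read-out lower numbers stand for stronger inhibition and higher numbers for weaker inhibition), the lower of the pair measured so far; its nearest neighbour is compound 1 `Cc1ccc(C#Cc2cn(C/C=C\CN3C(=O)c4ccccc4C3=O)c(=O)[nH]c2=O)cc1`, which gives 68000 nM in this assay, and the two sit within the scatter of each other. Among the compounds with values here, the only measured step, a 1.7-fold lower number from compound 1 to compound 2 (0.24 log units; within the scatter), replaced 4-methylphenyl on the triple-bonded carbon with octyl and moved the number by less than the scatter.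

Compound 3 `O=C1c2ccccc2C(=O)N1C/C=C\Cn1cc(C#Cc2ccc(Br)cc2)c(=O)[nH]c1=O` is the unmeasured member. It differs from compound 2 by 4-bromophenyl in place of octyl on a triple-bonded carbon. This change bears directly on the measured step: it returns an aromatic ring to the same triple-bonded carbon, much as compound 1 carries one, with bromine in place of methyl. Because that step, a 1.7-fold lower number from compound 1 to compound 2 (0.24 log units; within the scatter), stayed within the scatter, no shift beyond the scatter is expected here either; if anything, a slightly higher number, toward the value of compound 1, is expected. For compound 3 the estimate in this assay is 55000 nM (range 25000 nM to 120000 nM), which corresponds to an expected step of a 1.4-fold higher number from compound 2 to compound 3 (0.15 log units; within the scatter).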

Compound 3, half-maximal inhibitory concentration: 89000 nM
Beside the measured number, compound 3's estimate is 1.6-fold (0.21 log units) below it; measured number inside the range.
By their numbers in this assay, from the lowest: compounds 2, 1 and 3 (each within the scatter of the next, the first and the last beyond it).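

Within the data shown here, on the triple-bonded carbon, the change read as a 2.3-fold higher number from compound 2 to compound 3 (0.36 log units; beyond the scatter) in this assay is the only one of the three steps to pass the scatter, and only modestly, so the group at this position can move the number to a small degree. The comparison of the two aromatic groups, read as a 1.3-fold higher number from compound 1 to compound 3 (0.12 log units; within the scatter) for bromo in place of methyl on an aromatic carbon, stays within the scatter, so this change on the ring does not separate the two compounds. Octyl thus parts from 4-bromophenyl but not from 4-methylphenyl, as the step read as a 1.7-fold lower number from compound 1 to compound 2 (0.24 log units; within the scatter) stays within the scatter, which means that no general split between chain and aromatic ring holds across the three compounds, with compound 1 going against it.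

A reason for these small differences cannot be given from the data at hand.

Still open, on these data alone, is whether a group of another kind on the triple-bonded carbon, such as a longer chain than octyl, a chain ending in an amine or a carboxylic acid, or a ring carrying a methoxy group, would shift the number by more than these modest steps.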